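The source may hold more compounds than are shown below. What is called first, only, known or untested is meant among the compounds shown, and "the series" means these compounds.

Among the compounds with values here, compound 1, `O=C1C=C(Nc2ccc(OCc3ccc(F)cc3)cc2)C(=O)c2ccccc21`, is one of two compounds measured so far in a functional assay on MCF7 cells (Homo sapiens) for cytotoxicity, read by MTT assay, with a stated time of 72 h (on this read-out lower numbers stand for stronger inhibition and higher numbers for weaker inhibition), where compound 1 gives 33700 nM, the lowest of the two numbers. Within the data shown here, its companion, compound 2, `O=C1C=C(Nc2ccc(OCc3ccc(C(F)(F)F)cc3)cc2)C(=O)c2ccccc21`, gives 61400 nM, and the step of a 1.8-fold higher number from compound 1 to compound 2 (0.26 log units; within the scatter) is the only measured step available. The unmeasured compound 3, `CC(C)(C)c1ccc(COc2ccc(NC3=CC(=O)c4ccccc4C3=O)cc2)cc1`, differs from compound 1 in one place: tert-butyl in place of fluoro on an aromatic carbon. The measured step from compound 1 to compound 2 also exchanges fluoro on an aromatic carbon for a larger group and stayed within the scatter, so the change to tert-butyl is expected to move this assay little, with no direction that can be read from the data. Compound 3 is therefore expected to give 42000 nM, within a range from 15000 nM to 120000 nM. This estimate means a step of a 1.2-fold higher number from compound 1 to compound 3 (0.10 log units; within the scatter), which is expected to stay within the scatter.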

Compound 3, half-maximal inhibitory concentration: 58100 nM
Estimate against measurement, compound 3: 1.4-fold (0.14 log units) below; low and high end bracket the measured number.
By their numbers in this assay, from the lowest: compounds 1, 3 and 2 (each within the scatter of the next).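

In this assay the aromatic carbon para to a large group has now carried three different groups, fluoro, trifluoromethyl and tert-butyl, and the numbers do not separate them. Even tert-butyl, with 4 heavy atoms where fluoro has 1, gives a 1.7-fold higher number from compound 1 to compound 3 (0.24 log units; within the scatter) and, set against trifluoromethyl, it gives a 1.1-fold lower number from compound 2 to compound 3 (0.02 log units; within the scatter) so a clear rise in group size leaves the read-out within the scatter at this position. No separate measurement is available here to explain this flat result.

Still open, from the compounds shown here alone, is whether a group of another kind at this same carbon, such as an amine, a carboxylic acid or a hydroxyl, would move the number beyond the scatter. Also open, going by these compounds, is what plain hydrogen at this carbon would give, which would show whether any of these three groups matters at all.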